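Methoxy in Place of Hydrogen: What to Expect for Compound 3

The source may hold more compounds than are shown below. What is called first, only, known or untested is meant among the compounds shown, and "the series" means these compounds.

Measured so far:
Compound 1 `COc1cc(/C=N/N(C)c2nc3ccccc3s2)cc(OC)c1O` gives 5% in a physicochemical assay on cells (Homo sapiens), with a stated time of 18 h, tested at 1 uM; a lower number here means a stronger effect, a higher number a weaker effect of the compound at the concentration tested.
Compound 2 `Oc1ccc(/C=N/Nc2nc3ccccc3s2)cc1O` gives 44% in this assay.

Of these two numbers compound 2 gives the higher one, and its gap to compound 1 lies beyond the usual scatter. Compound 3 `COc1cc(/C=N/Nc2nc3ccccc3s2)cc(O)c1O` differs from compound 2 by methoxy in place of hydrogen on an aromatic carbon. Going by the values given here, no step between measured compounds is available, so a moderate downward step in this assay is expected, because compound 1 with its methoxy groups gives 5%. Compound 3 is therefore estimated at 28%, ranging from 8% to 50%. The expected step is a number 16 percentage points lower from compound 2 to compound 3 (beyond the scatter).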

Compound 3, a percentage reported as activity, at one concentration (the size of the read-out at that concentration, not a potency): 56%
Compound 3: middle estimate off by 28 percentage points, on the low side; the whole stated range lies below it.
By their numbers in this assay, from the lowest: compound 1; then compound 2; then compound 3.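

In this assay methoxy in place of hydrogen, ortho to a hydroxy group and meta to a large group, gives a number 12 percentage points higher from compound 2 to compound 3 (beyond the scatter) and thus a modestly weaker effect. This single change therefore does not move the number towards the low value of compound 1, whose other differences remain unseparated. Nothing available explains the step.
From the compounds shown here alone, whether an amine or a longer chain such as ethoxy in the same place would give a lower or a higher number stays open. Which feature of compound 1 goes with its 5% also stays open.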